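Shortening the alkyne tail: hexyl to cyclopropyl

The source may report more compounds than this note shows. Statements on the series, on what has been measured and on what is new or still open speak of the compounds shown alone.

Measured so far:
compound 1 `CCCCCCC#Cc1cn([C@@H]2O[C@H](CO)[C@@H](O)[C@H]2O)c(=O)[nH]c1=O` gives 87200 nM in an ADME assay on A549 cells (Homo sapiens) for cytotoxicity, read by MTT assay; a lower number here means that less compound is tolerated, a higher number that more compound is tolerated
compound 2 `O=c1[nH]cc(C#CC2CCCCC2)c(=O)[nH]1` gives 245000 nM in this assay

Compound 1 holds the lowest of the two numbers in this assay; compound 2 lies clearly higher, beyond the usual scatter. Compound 3 `O=c1[nH]c(=O)n([C@@H]2O[C@H](CO)[C@@H](O)[C@H]2O)cc1C#CC1CC1` is not yet measured. It differs from compound 1 by cyclopropyl in place of hexyl on a triple-bonded carbon, a trimming of the tail on the triple bond. For the measured compounds named here, with no measured pair showing this exact change, the step is expected to be modest, most likely upward, by about a 1.7-fold higher number from compound 1 to compound 3 (0.24 log units; within the scatter). Compound 3 is therefore estimated at 150000 nM, somewhere from 60000 nM to 400000 nM.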

Compound 3, half-maximal cytotoxic concentration: 115000 nM
Compound 3: the middle estimate sits 1.3-fold (0.12 log units) above what was measured; low and high end bracket the measured number.
By their numbers in this assay, from the lowest: compounds 1 and 3 (each within the scatter of the next); then compound 2.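

Cyclopropyl in place of hexyl on a triple-bonded carbon gives a 1.3-fold higher number from compound 1 to compound 3 (0.12 log units; within the scatter) in this assay and so leaves the reading within the scatter. At this position, a small three-membered ring and an open six-carbon chain therefore cannot be told apart in this test. No measured evidence explains this result. Still open, on these data alone, is whether an amine or a carboxylic acid on the end of the triple bond would also stay within the scatter. A longer chain at this place remains equally untested among the compounds shown.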